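Methoxy to Methyl: A Small Change on a Shared Core

A few compounds are considered here, and "the series" means these few. Any claim that something is new, unique, unknown or untested is made for them only; others in the source may bear on it.

Compound 1, `O=c1c2ccccc2[se]n1-c1nnc(-c2ccc(Br)cc2)s1`, gives 68200 nM in a functional assay on SSMC-7721 cells (Homo sapiens) for antiproliferative activity, read by CCK-8 assay, with a stated time of 48 h; a lower number here means a stronger inhibitor, a higher number a weaker inhibitor.
Compound 2, `COc1ccc(-c2nnc(-n3[se]c4ccccc4c3=O)s2)cc1`, gives 16500 nM.
Compound 3, `O=c1c2ccccc2[se]n1-c1nnc(-c2ccccc2Cl)s1`, gives 40200 nM.

Among the three measured compounds, compound 2 has the lowest number in this assay. The step of a 4.1-fold lower number from compound 1 to compound 2 (0.62 log units; beyond the scatter) is beyond the scatter, and the number for compound 3 is also higher than that of compound 2. The unmeasured compound 4, `Cc1ccc(-c2nnc(-n3[se]c4ccccc4c3=O)s2)cc1`, differs from compound 2 by a single change: methyl in place of methoxy on an aromatic carbon.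

For the measured compounds named here, only one measured step touches the same place on the ring: a 4.1-fold lower number from compound 1 to compound 2 (0.62 log units; beyond the scatter), where a methoxy group replaced a bromo group and the number fell modestly. The other step, a 1.7-fold lower number from compound 1 to compound 3 (0.23 log units; within the scatter), concerns a different place and a different group and stayed within the scatter, so it says little here. Going by the values given here, with only one bearing step, and no measured compound carrying a methyl at that place, the expectation is cautious: a small move back toward a higher number, or no change beyond the scatter, is expected, that is a 1.5-fold higher number from compound 2 to compound 4 (0.18 log units; within the scatter). Compound 4 is therefore estimated at 25000 nM, with a range from 10000 nM to 60000 nM.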

Compound 4, half-maximal inhibitory concentration: 16600 nM
Beside the measured number, compound 4's estimate is 1.5-fold (0.18 log units) above it; measured number inside the range.
By their numbers in this assay, from the lowest: compounds 2 and 4 (each within the scatter of the next); then compounds 3 and 1 (each within the scatter of the next).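

Methyl in place of methoxy gives a 1.0-fold higher number from compound 2 to compound 4 (0.00 log units; within the scatter) in this assay, so at this place, para to a large group, the two groups cannot be told apart, even though the methoxy oxygen and its hydrogen-bond acceptor leave. Methyl in place of bromo gives a 4.1-fold lower number from compound 1 to compound 4 (0.61 log units; beyond the scatter) and 4-methylphenyl in place of 2-chlorophenyl gives a 2.4-fold lower number from compound 3 to compound 4 (0.38 log units; beyond the scatter), which shows that the earlier step away from bromo is not tied to methoxy alone. Nothing measured here gives a reason for these readings.

The compounds shown leave open how an amine, a carboxylic acid or a longer chain such as ethoxy would read at this same place. They also leave open whether methyl and methoxy stay alike at any other place on this ring.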